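A few compounds are considered here, and "the series" means these few. Any claim that something is new, unique, unknown or untested is made for them only; others in the source may bear on it.

Within the data shown here, compound 3 `O=c1[nH]/c(=N\OCCCc2cccc([N+](=O)[O-])c2)ccn1[C@@H]1O[C@H](COP(=O)(O)OP(=O)(O)OP(=O)(O)O)[C@@H](O)[C@H]1O` gives 9700 nM in a functional assay on 1321-N1 cells for agonist activity at P2Y purinoceptor 6 (Homo sapiens), read by scintillation counting and inositol phosphate accumulation (a lower number here means that less compound is needed, a higher number that more compound is needed for the effect), the highest of the three numbers so far: compound 1 `O=c1[nH]/c(=N\OCCCc2cccc(I)c2)ccn1[C@@H]1O[C@H](COP(=O)(O)OP(=O)(O)OP(=O)(O)O)[C@@H](O)[C@H]1O` gives 299 nM and compound 2 `O=c1[nH]/c(=N\OCCCc2ccc(I)cc2)ccn1[C@@H]1O[C@H](COP(=O)(O)OP(=O)(O)OP(=O)(O)O)[C@@H](O)[C@H]1O` gives 90 nM. Compound 4 `O=c1[nH]/c(=N\OCCCc2ccsc2)ccn1[C@@H]1O[C@H](COP(=O)(O)OP(=O)(O)OP(=O)(O)O)[C@@H](O)[C@H]1O` differs from compound 3 by thiophen-3-yl in place of 3-nitrophenyl on a saturated chain carbon, three bonds along the chain from an oxygen. Among the measured compounds shown here, no measured step brings in a thiophen-3-yl, but two steps bear on leaving the nitro behind: the step of a 32-fold higher number from compound 1 to compound 3 (1.51 log units; beyond the scatter) and the step of a 110-fold higher number from compound 2 to compound 3 (2.03 log units; beyond the scatter), both large. Undoing that change is therefore expected to lower the number, though no iodo returns, so the step of a 9.7-fold lower number from compound 3 to compound 4 (0.99 log units; beyond the scatter) is expected to be smaller than either of those. Compound 4 is expected to give about 1000 nM, with a likely range from 200 nM to 5000 nM.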

Compound 4, half-maximal effective concentration: 164 nM
Beside the measured number, compound 4's estimate is 6.1-fold (0.79 log units) above it; measured number below the stated range.
By their numbers in this assay, from the lowest: compounds 2, 4 and 1 (each within the scatter of the next, the first and the last beyond it); then compound 3.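

Iodine is not required at this position: the thiophen-3-yl, a five-membered ring carrying no iodo group, gives a 59-fold lower number from compound 3 to compound 4 (1.77 log units; beyond the scatter) and sits within the scatter of both iodinated compounds, with a 1.8-fold higher number from compound 2 to compound 4 (0.26 log units; within the scatter) and a 1.8-fold lower number from compound 1 to compound 4 (0.26 log units; within the scatter). Among these four compounds, only the 3-nitrophenyl compound stands apart. Nothing available explains why this ring performs so much better than the 3-nitrophenyl.

From the compounds shown here alone, it remains open whether a plain phenyl or furan ring on the same chain would give a similar number. Going by these compounds, the effect of a longer chain also remains open.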